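A Single Aryl Swap on a Growth Inhibitor

This account rests on a few compounds, and the source may have more. Where it says the series, first, only, none or still open, it means among the compounds named here.

Among the measured compounds shown here, in a functional assay on SW-620 cells (Homo sapiens) for cytotoxicity (a lower number here means a stronger inhibitor of growth, a higher number a weaker inhibitor of growth), compound 1 (`CSc1ccc(C2=C(c3ccc(F)c(C)c3)C(=O)N3CCCC3C2)cc1`) gives 600 nM and so holds the lower of the two numbers measured so far. Compound 2 (`COc1ccc(C2=C(c3ccc(SC)cc3)CC3CCCN3C2=O)cc1OC`) gives 3000 nM in this assay and lies beyond the usual scatter from compound 1. These two compounds differ in more than one place, so no measured single change is available as a guide.

Compound 3 (`CSc1ccc(C2=C(c3ccc(Br)cc3)C(=O)N3CCCC3C2)cc1`) keeps the 4-(methylsulfanyl)phenyl group of compound 1 and alters the group on the neighbouring double-bonded ring carbon. It has 4-bromophenyl in place of 4-fluoro-3-methylphenyl (4-bromophenyl in place of 4-fluoro-3-methylphenyl on a double-bonded ring carbon) on that carbon.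

Both groups are built on one six-membered aromatic ring of carbon only, and the closest measured relative is compound 1 at 600 nM as the starting point. The expected change is small, a slight rise at most that stays within the scatter, and it is estimated as a 1.3-fold higher number from compound 1 to compound 3 (0.12 log units; within the scatter) in this assay for now. Compound 3 is estimated at 800 nM with an expected range from 250 nM to 2500 nM in this measurement.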

Compound 3, concentration for 50% growth inhibition: 7000 nM
Estimate against measurement, compound 3: 8.8-fold (0.94 log units) below, outside the stated range (above it).
By their numbers in this assay, from the lowest: compound 1; then compound 2; then compound 3.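

In this assay, among the compounds shown here, placing 4-bromophenyl in place of 4-fluoro-3-methylphenyl on the double-bonded ring carbon gives a 12-fold higher number from compound 1 to compound 3 (1.07 log units; beyond the scatter) and is the first single change that can be read directly. This position is therefore sensitive to which aryl group it carries, even though the leaving and entering groups are each built on one six-membered aromatic ring of carbon only, with no hydrogen-bond donors or acceptors and no net charge. Matching counts of this kind were no guide to the result here, and no measurement shown offers an explanation for this step.

The swap changes two things at once: the methyl group goes, and bromine takes the place of fluorine, so the compounds shown cannot tell which of these accounts for the step, or whether both are needed. On these data alone, it also remains open whether a 4-fluorophenyl group, a 4-chlorophenyl group or a phenyl ring bearing an amine on this carbon would give a number closer to that of compound 1 or to that of compound 3.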